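The compounds below may be only part of what the source reports. "The series", "measured", "known", "first", "only" and "open" are said of these compounds alone.

Working notes on the series. Among the measured compounds shown here, in a toxicity assay on Vero cells (Chlorocebus sabaeus) for cytotoxicity, read by colorimetric assay and MTT assay, with a stated time of 72 h (a lower number here means that less compound is tolerated, a higher number that more compound is tolerated), compound 1 (`Nc1cccc(F)c1C(=O)NNc1ccccc1Cl`) gives 792000 nM, the only actual number available so far. Compound 2 (`Nc1cccc(F)c1C(=O)NNc1cccc(Cl)c1Cl`) reads > 1800000 nM, which is a limit of the assay and not a number.

The next compound to consider is compound 3 (`Nc1cccc(F)c1C(=O)NNc1ccc(Cl)cc1Cl`). The change is chloro in place of hydrogen on an aromatic carbon, meta to a chloro group and para to a large group.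

For the measured compounds named here, one measured step bears on this, an at least 2.2-fold higher number from compound 1 to compound 2 (0.35 log units; beyond the scatter). It is the same kind of exchange, made at a different carbon of the ring, and it lies beyond the scatter. Going by the values given here, because only this one step is available, and its size is a bound rather than a number, the read-across is loose. A modest move towards a higher number in this assay is expected, and a result within the scatter would not be surprising. The expected size is a 1.8-fold higher number from compound 1 to compound 3 (0.25 log units; within the scatter). A reading that comes back only as a limit is also possible. The estimated value for compound 3 is 1400000 nM, with an expected range of 700000 nM to 2800000 nM.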

Compound 3, half-maximal cytotoxic concentration: 1040000 nM
Estimate against measurement, compound 3: 1.3-fold (0.13 log units) above; low and high end bracket the measured number.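

In this assay, chloro in place of hydrogen on this aromatic carbon, meta to a chloro group and para to a large group, gives a 1.3-fold higher number from compound 1 to compound 3 (0.12 log units; within the scatter), so the exchange here cannot be told apart from no change. The earlier exchange at a different carbon of the ring gave an at least 2.2-fold higher number from compound 1 to compound 2 (0.35 log units; beyond the scatter), so the series now shows that this exchange does not give a step beyond the scatter at every carbon of the ring. Compound 2 stands at a limit of the assay and not a number, so the earlier step remains a bound and the difference between the two carbons cannot be sized: the limit of > 1800000 nM in this assay, at which 1 of the 3 values shown sits.

The compounds shown leave open whether a group other than chloro on this carbon, such as a methoxy group, an amine or a carboxylic acid, would give a step beyond the scatter. They also leave open whether the contrast between the two carbons would hold with such a group, since chloro is the only group entering the ring in the steps shown.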